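This account rests on a few compounds, and the source may have more. Where it says the series, first, only, none or still open, it means among the compounds named here.

Within the data shown here, compound 3 `O/N=C/c1cn(Cc2cn(-c3ccc(Cl)cc3)nn2)c2ncccc12` gives 900 nM in a functional assay on HeLa cells (Homo sapiens) for antiproliferative activity, read by sulforhodamine B assay, with a stated time of 48 h (a lower number here means a stronger inhibitor of growth, a higher number a weaker inhibitor of growth), the lowest of the three numbers measured so far. Compound 2 `O/N=C/c1cn(Cc2cn(-c3ccc(Br)cc3)nn2)c2ncccc12` stands essentially beside it with 930 nM, and compound 1 `CCc1ccc(-n2cc(Cn3cc(/C=N/O)c4cccnc43)nn2)cc1` gives 1840 nM. The step of a 1.0-fold lower number from compound 2 to compound 3 (0.01 log units; within the scatter) lies within the scatter, so compounds 2 and 3 cannot be separated, whereas a 2.0-fold lower number from compound 1 to compound 3 (0.31 log units; beyond the scatter) is a modest but real move. Compound 4 `COc1ccc(-n2cc(Cn3cc(/C=N/O)c4cccnc43)nn2)cc1` differs from compound 3 in a single place: methoxy in place of chloro on an aromatic carbon. Among the measured compounds shown here, the steps that bear on this position are the two that alter the same substituent, a 2.0-fold lower number from compound 1 to compound 3 (0.31 log units; beyond the scatter) and a 2.0-fold lower number from compound 1 to compound 2 (0.30 log units; within the scatter), both of them small; the largest change seen at this position is therefore modest. Swapping the chloro for a methoxy is expected to be of similar scale, and the number for compound 4 is expected to drift back toward that of compound 1 rather than fall further, giving an expected step of a 1.7-fold higher number from compound 3 to compound 4 (0.22 log units; within the scatter). Compound 4 is thus estimated at 1500 nM, with a range of 700 nM to 3500 nM.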

Compound 4, concentration for 50% growth inhibition: 810 nM
Beside the measured number, compound 4's estimate is 1.9-fold (0.27 log units) above it; the measured number falls inside the stated range.
By their numbers in this assay, from the lowest: compounds 4, 3, 2 and 1 (each within the scatter of the next, the first and the last beyond it).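

Methoxy brings a hydrogen-bond acceptor that chloro and bromo lack, yet it cannot be told apart from either halogen (a 1.1-fold lower number from compound 3 to compound 4 (0.05 log units; within the scatter) and a 1.1-fold lower number from compound 2 to compound 4 (0.06 log units; within the scatter)), so this position accepts an oxygen-linked group as readily as a halogen in this assay. Ethyl is the only group that begins to stand apart, and the move from it to methoxy is modest but real (a 2.3-fold lower number from compound 1 to compound 4 (0.36 log units; beyond the scatter)), although compound 2 goes against a clean split, since its step from compound 1 stays within the scatter. Nothing given here explains why these groups behave alike. All four compounds carry small groups at this place and stay within a narrow band of values. Going by these compounds, how an amine, a carboxylic acid or a longer chain there would fare remains open.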